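Swapping one halogen for another on the carbamate ring

The source may report more compounds than this note shows. Statements on the series, on what has been measured and on what is new or still open speak of the compounds shown alone.

Three compounds sharing one core were tested in a functional assay on PANC-1 cells (Homo sapiens) for inhibition, read by MTT assay, with a stated time of 24 h, tested at 10 uM; a lower number here means less inhibition, a higher number more inhibition at the concentration tested (going by the name of the read-out). Compound 1 `CC(C)=CCC/C(C)=C/CC1Cc2c(OCC=C(C)C)cc(=O)n(CCCO)c2CC1(C)C` gives 15.9%. Compound 2 `COc1cccc(NC(=O)Oc2cc(=O)n(CCCO)c3c2CC(C/C=C(\C)CCC=C(C)C)C(C)(C)C3)c1` gives 11.3%, and compound 3 `CC(C)=CCC/C(C)=C/CC1Cc2c(OC(=O)Nc3ccc(F)c(F)c3)cc(=O)n(CCCO)c2CC1(C)C` gives 4.8%. Compound 3 sits at the low end of the three numbers: the step of a number 6.5 percentage points lower from compound 2 to compound 3 (within the scatter) stays within the scatter, while a number 11.1 percentage points lower from compound 1 to compound 3 (beyond the scatter) goes beyond it, so only the distance to compound 1 can be called a real difference.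

Compound 4 `CC(C)=CCC/C(C)=C/CC1Cc2c(OC(=O)Nc3ccc(F)c(Cl)c3)cc(=O)n(CCCO)c2CC1(C)C` differs from compound 3 in a single spot: chloro in place of fluoro on an aromatic carbon. Among the measured compounds shown here, the only measured step that touches the same aryl ring of the carbamate is a number 6.5 percentage points lower from compound 2 to compound 3 (within the scatter), and it was within the scatter even though a methoxy group gave way to two fluorines. The two other steps, a number 4.6 percentage points lower from compound 1 to compound 2 (within the scatter) and a number 11.1 percentage points lower from compound 1 to compound 3 (beyond the scatter), replace the whole prenyl group on the oxygen and so say little about a halogen swap. For the measured compounds named here, with one small atom exchanged for another and no step of this sort on record beyond the scatter, no shift outside the scatter is expected in this assay for compound 4.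

Compound 4 is therefore estimated to give 6%, in a range from -2% to 16%, which is the expected step of a number 1.2 percentage points higher from compound 3 to compound 4 (within the scatter).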

Compound 4, a percentage reported as inhibition, at one concentration (the size of the read-out at that concentration, not a potency): 0%
The estimate for compound 4 lay 6 percentage points above the measured number, within the range that was stated.
By their numbers in this assay, from the lowest: compounds 4, 3, 2 and 1 (each within the scatter of the next, the first and the last beyond it).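

Exchanging fluoro for chloro on this aromatic carbon, ortho to a fluoro group and meta to a large group, gives no real change in this assay: the step is a number 4.8 percentage points lower from compound 3 to compound 4 (within the scatter), so the 3,4-difluorophenyl and 3-chloro-4-fluorophenyl rings cannot be told apart here. The swap does add one distinction, since the 3-chloro-4-fluorophenyl carbamate separates from the 3-methoxyphenyl carbamate with a number 11.3 percentage points lower from compound 2 to compound 4 (beyond the scatter) and from the compound carrying 3-methylbut-2-en-1-yl on the oxygen with a number 15.9 percentage points lower from compound 1 to compound 4 (beyond the scatter), whereas compound 3 stayed within the scatter of compound 2. No measurement at hand accounts for any of these steps.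

From the compounds shown here alone, whether bromo, or a larger change such as an amine or a carboxylic acid, on this same ring carbon would move the number beyond the scatter of compound 3 remains open. Each number also comes from a single concentration, so these compounds leave open how their potencies compare, which a full concentration series in PANC-1 cells would be needed to show.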